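The compounds below may be only part of what the source reports. "The series", "measured", "known", "first", "only" and "open" are said of these compounds alone.

Measured so far:
Compound 1, `CC[C@@H](Nc1nc(NCc2ccccn2)c2ncn(C(C)C)c2n1)C(C)(C)O`: > 50000 nM
Compound 2, `CC[C@@H](Nc1nc(NCc2ccccn2)c2ncn(C(C)C)c2n1)C(O)C(C)(C)C`: 45000 nM

In a functional assay on KM12 cells (Homo sapiens) for inhibition, read by sulforhodamine B assay, with a stated time of 96 h (on this read-out lower numbers stand for stronger inhibition of growth and higher numbers for weaker inhibition of growth), compound 1 reaches only the limit of the assay, > 50000 nM, and gives no number. Compound 2 gives 45000 nM; it holds the only number shown. Within the data shown here, the one further value shown is the limit reached by compound 1. The step between them, an at least 1.1-fold lower number from compound 1 to compound 2 (0.04 log units; that floor lies within the scatter), is a floor within the scatter, so the two compounds cannot be told apart.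

Compound 3, `CC[C@H](Nc1nc(NCc2ccccn2)c2ncn(C(C)C)c2n1)C(C)(C)O`, has not been measured. It changes compound 2 by 1-(1-hydroxy-1-methylethyl)propyl in place of 1-ethyl-2-hydroxy-3,3-dimethylbutyl on a nitrogen on an aromatic ring. Among the measured compounds shown here, the entering group is the one lost in the step from compound 1 to compound 2, so that step, read backwards, is the only guide, and it promises no change beyond the scatter, with a fair chance that compound 3 again reaches only the limit (the limit of > 50000 nM in this assay, at which 1 of the 2 values shown sits).

Compound 3 is therefore expected near 60000 nM, in the range 30000 nM to 150000 nM, an estimated step of a 1.3-fold higher number from compound 2 to compound 3 (0.12 log units; within the scatter).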

Compound 3, concentration for 50% growth inhibition: 38000 nM
The estimate for compound 3 lay 1.6-fold (0.20 log units) above the measured number; low and high end bracket the measured number.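

The change on the nitrogen gives a 1.2-fold lower number from compound 2 to compound 3 (0.07 log units; within the scatter), so in this assay the 1-(1-hydroxy-1-methylethyl)propyl and 1-ethyl-2-hydroxy-3,3-dimethylbutyl groups cannot be told apart. Compounds 1 and 3 are the first pair shown that isolates the drawn configuration, R against S at a single stereocentre, and they give an at least 1.3-fold lower number from compound 1 to compound 3 (0.11 log units; that floor lies within the scatter). That step is only a floor, because compound 1 reached a limit rather than a number: the limit of > 50000 nM in this assay, at which 1 of the 3 values shown sits.

Going by these compounds, how far the true value of compound 1 lies from that of compound 3 stays open, so the weight of this stereocentre is unknown. Also open, on these data alone, is whether a different kind of group on this nitrogen, such as a chain ending in an amine or a carboxylic acid, would give a number clearly apart from these.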